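The compounds below may be only part of what the source reports. "The series", "measured", "known", "first", "only" and "open" are said of these compounds alone.

In a functional assay on THP-1 cells (Homo sapiens) for cytotoxicity, read by sulforhodamine B assay, with a stated time of 48 h (on this read-out lower numbers stand for stronger inhibition and higher numbers for weaker inhibition), three compounds sharing one core have been measured. Compound 1 `COc1cc(/C=C/C(=O)/C=C/c2cccs2)ccc1OCc1cn(CCOc2cc(=O)oc3ccccc23)nn1` gives 7140 nM, and compound 2 `COc1cc(/C=C/C(=O)/C=C/c2cc(OC)c(OC)c(OC)c2)ccc1OCc1cn(CCOc2cc(=O)oc3ccccc23)nn1` gives 820 nM. Compound 3 `COc1ccc(/C=C/C(=O)/C=C/c2ccc(OCc3cn(CCOc4cc(=O)oc5ccccc45)nn3)c(OC)c2)cc1OC` gives 2340 nM, the second highest of the three numbers. Compound 4 `COc1ccccc1/C=C/C(=O)/C=C/c1ccc(OCc2cn(CCOc3cc(=O)oc4ccccc34)nn2)c(OC)c1` departs from compound 3 at one place: 2-methoxyphenyl in place of 3,4-dimethoxyphenyl on a double-bonded chain carbon bound to a double-bonded chain carbon. This puts 2-methoxyphenyl in place of 3,4-dimethoxyphenyl on a double-bonded chain carbon bound to a double-bonded chain carbon.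

The closest evidence is a 2.9-fold higher number from compound 2 to compound 3 (0.46 log units; beyond the scatter), a modest rise beyond the scatter when hydrogen replaces methoxy on an aromatic carbon. Within the data shown here, the other two steps, a 3.1-fold lower number from compound 1 to compound 3 (0.48 log units; beyond the scatter) and an 8.7-fold lower number from compound 1 to compound 2 (0.94 log units; beyond the scatter), are also modest and show that the thiophen-2-yl compound has the highest number so far. Among the measured compounds shown here, no measured compound carries 2-methoxyphenyl, so the direction rests on that single hydrogen-for-methoxy comparison. A small rise is therefore expected, smaller than that comparison and possibly within the scatter. The expected change is a 1.5-fold higher number from compound 3 to compound 4 (0.17 log units; within the scatter). Compound 4 is estimated at 3500 nM, with an expected range from 1300 nM to 9000 nM.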

Compound 4, half-maximal inhibitory concentration: 7330 nM
Compound 4: the middle estimate sits 2.1-fold (0.32 log units) below what was measured; the measured number falls inside the stated range.
By their numbers in this assay, from the lowest: compound 2; then compound 3; then compounds 1 and 4 (each within the scatter of the next).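

In this assay the group at this position now spans the full spread of the series: a 3.1-fold higher number from compound 3 to compound 4 (0.50 log units; beyond the scatter) and an 8.9-fold higher number from compound 2 to compound 4 (0.95 log units; beyond the scatter) both lie beyond the scatter, and the number falls in the order 2-methoxyphenyl in compound 4, 3,4-dimethoxyphenyl in compound 3, 3,4,5-trimethoxyphenyl in compound 2. The third step, a 1.0-fold higher number from compound 1 to compound 4 (0.01 log units; within the scatter), lies within the scatter, so 2-methoxyphenyl and thiophen-2-yl cannot be told apart here. A single methoxy group on the phenyl ring is therefore not enough to separate compound 4 from compound 1. Nothing at hand explains these steps.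

The compounds shown leave open whether the count of methoxy groups or their placing on the ring governs the number. They also leave open how a phenyl ring bearing an amine or a carboxylic acid would read at this position.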